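The compounds below may be only part of what the source reports. "The series", "measured", "known", "first", "only" and "open" are said of these compounds alone.

Within the data shown here, in a functional assay on NCI-H460 cells (Homo sapiens) for antiproliferative activity, read by CCK-8 assay, with a stated time of 72 h, tested at 2 uM (a higher number here means a stronger effect of the compound at the concentration tested, a lower number a weaker effect), compound 3 `CC(C)n1cnc2c(Nc3cccc(Cl)c3)nc(NCOCc3ccc(C(=O)Nc4ccccc4N)cc3)nc21` gives 28.9%, the second highest of the three numbers measured so far. Compound 1 `CCCCn1cnc2c(Nc3cccc(Cl)c3)nc(NCOCc3ccc(/C=C/C(=O)Nc4ccccc4N)cc3)nc21` gives 25.7%, a number within the scatter of compound 3, while compound 2 `CC(C)n1cnc2c(Nc3ccccc3)nc(NCOCc3ccc(/C=C/C(=O)Nc4ccccc4N)cc3)nc21` gives 41%, higher than compound 3 by more than the scatter. Compound 4 `CC(C)n1cnc2c(Nc3cccc(Cl)c3)nc(NCOCc3ccc(/C=C/C(=O)Nc4ccccc4N)cc3)nc21` differs from compound 3 in one place: 2-((2-aminophenyl)carbamoyl)ethenyl in place of (2-aminophenyl)carbamoyl on an aromatic carbon. Compound 1 and compound 2 both already carry the entering group. Among the measured compounds shown here, no pair of measured compounds differs in only one place, so there is no measured step to lean on; the step is expected to be a number 4.1 percentage points higher from compound 3 to compound 4 (within the scatter) in this assay, none beyond the scatter. Compound 4 is therefore expected to give about 33% in this assay, estimated between 20% and 48%.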

Compound 4, a percentage reported as inhibition, at one concentration (the size of the read-out at that concentration, not a potency): 53%
The estimate for compound 4 lay 20 percentage points below the measured number; the measured number lies above the stated range.
By their numbers in this assay, from the lowest: compounds 1 and 3 (each within the scatter of the next); then compound 2; then compound 4.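

In this assay, 2-((2-aminophenyl)carbamoyl)ethenyl in place of (2-aminophenyl)carbamoyl on an aromatic carbon gives a number 24.1 percentage points higher from compound 3 to compound 4 (beyond the scatter). With that group in place, chloro in place of hydrogen on an aromatic carbon gives a number 12 percentage points higher from compound 2 to compound 4 (beyond the scatter), and isopropyl in place of butyl on an aromatic nitrogen gives a number 27.3 percentage points higher from compound 1 to compound 4 (beyond the scatter). No evidence on the cause of these steps is available. The compounds shown leave open whether a saturated ethyl link in place of the ethenyl would give a similar number. From the compounds shown here alone, whether fluoro or methoxy in place of chloro would do so also stays open.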